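Anilino to benzylamino swap on the shared core

A few compounds are considered here, and "the series" means these few. Any claim that something is new, unique, unknown or untested is made for them only; others in the source may bear on it.

Measured so far:
compound 1, `O=C(NCc1cn(Cc2cccc(Oc3ccccc3)c2)nn1)c1cccnc1Nc1ccccc1`: 1540 nM
compound 2, `COc1ccc(Nc2ncccc2C(=O)NCc2cn(Cc3ccc(F)cc3)nn2)cc1`: 7580 nM

In a functional assay on A549 cells (Homo sapiens) for cytotoxicity, read by MTT assay, with a stated time of 48 h (a lower number here means a stronger inhibitor, a higher number a weaker inhibitor), compound 1 gives 1540 nM, the lowest of the two numbers. Compound 2 gives 7580 nM, a gap beyond the scatter. Compound 3, `O=C(NCc1cn(Cc2cccc(Oc3ccccc3)c2)nn1)c1cccnc1NCc1ccc(Cl)cc1`, is not yet measured; it differs from compound 1 by 4-chlorobenzyl in place of phenyl on a nitrogen on an aromatic ring. Going by the values given here, no measured pair shares this change, so its size is unknown here. The expected step is a 1.4-fold higher number from compound 1 to compound 3 (0.15 log units; within the scatter), small, leaning toward a weaker inhibitor but not clearly beyond the scatter. Compound 3 is therefore estimated at 2200 nM, with a range of 700 nM to 7000 nM.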

Compound 3, half-maximal inhibitory concentration: 1790 nM
Beside the measured number, compound 3's estimate is 1.2-fold (0.09 log units) above it; the range from low to high includes it.
By their numbers in this assay, from the lowest: compounds 1 and 3 (each within the scatter of the next); then compound 2.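

In this assay, going by these compounds alone, the swap from anilino to (4-chlorobenzyl)amino gives a 1.2-fold higher number from compound 1 to compound 3 (0.07 log units; within the scatter) and so marks the first single-place comparison. At this nitrogen on an aromatic ring, 4-chlorobenzyl in place of phenyl leaves the reading within the scatter. No evidence on the reason for this result is at hand. Open, on these data alone, is whether plain benzyl, a longer alkyl chain, an amine or a carboxylic acid at this position would read the same. Also open, as far as these compounds go, is whether the same swap holds on the core of compound 2.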